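This account rests on a few compounds, and the source may have more. Where it says the series, first, only, none or still open, it means among the compounds named here.

Measured so far in a functional assay (Platelet, plasma) for inhibition, with Homo sapiens as the target; a lower number here means a stronger inhibitor, a higher number a weaker inhibitor:
compound 1 `N#Cc1cc2c(nc1N1CCC(C(=O)NS(=O)(=O)Cc3ccc(Cl)cc3)CC1)COC2=O` gives 4420 nM
compound 3 `N#Cc1cc2c(nc1N1CCC(F)(C(=O)NS(=O)(=O)c3ccc(Cl)s3)CC1)COC2=O` gives 37100 nM
compound 2 `CC1OC(=O)c2cc(C#N)c(N3CCC(C(=O)NS(=O)(=O)c4ccc(Cl)s4)CC3)nc21` gives > 300000 nM

Of the two numbers shown, compound 1 has the lower one, and its gap to compound 3 lies beyond the usual scatter of repeated measurements. For compound 2 this assay reports only a limit, (the limit of > 300000 nM in this assay, at which 1 of the 3 values shown sits), not a number.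

Compound 4 `N#Cc1cc2c(nc1N1CCC(C(=O)NS(=O)(=O)C3(c4ccccc4)CC3)CC1)COC2=O` is not yet measured. It differs from compound 1 in a single place: 1-phenylcyclopropyl in place of 4-chlorobenzyl on a sulfonyl sulfur. Among the measured compounds shown here, no pair of measured compounds differs in just this way, so nothing here fixes the size of the step. The groups leaving and entering are counted as close in size, without donors or acceptors on either side, so the step is expected to stay within the scatter: a 1.1-fold higher number from compound 1 to compound 4 (0.05 log units; within the scatter). Compound 4 is therefore estimated at 5000 nM, in a range from 1500 nM to 16000 nM.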

Compound 4, half-maximal inhibitory concentration: 4100 nM
Beside the measured number, compound 4's estimate is 1.2-fold (0.09 log units) above it; measured number inside the range.
By their numbers in this assay, from the lowest: compounds 4 and 1 (each within the scatter of the next); then compound 3. At a limit, above all of these: compound 2.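

In this assay, 1-phenylcyclopropyl in place of 4-chlorobenzyl gives a 1.1-fold lower number from compound 1 to compound 4 (0.03 log units; within the scatter), so the two compounds cannot be told apart. This place on the sulfonyl sulfur therefore holds either group, with or without the chlorine and with the added three-membered ring, at a similar number. Nothing measured here accounts for this match.

From the compounds shown here alone, the chlorine and the three-membered ring differ together, so their separate contributions stay unknown. Plain benzyl would separate them, while a group carrying an amine or a carboxylic acid would test how much else this place holds.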